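Swapping Nitro for Hydroxy on a Long-Chain Ketone Inhibitor

The compounds below may be only part of what the source reports. "The series", "measured", "known", "first", "only" and "open" are said of these compounds alone.

Compound 2 `O=C(CCCCCCc1ccccc1)c1ncc(-c2ccc([N+](=O)[O-])cc2)o1`: 50 nM
Compound 1 `Nc1ccccc1-c1cnc(C(=O)CCCCCCc2ccccc2)o1`: 750 nM

Of the compounds shown here, two have so far been measured in an assay (Rattus norvegicus) for inhibition of Fatty-acid amide hydrolase 1 (Homo sapiens); a higher number here means a weaker inhibitor, a lower number a stronger inhibitor. Compound 2 gives 50 nM, the lowest of the two numbers. Its nearest neighbour, compound 1, gives 750 nM. Going by the values given here, the one measured step between them is a 15-fold lower number from compound 1 to compound 2 (1.18 log units; beyond the scatter), a large move from a 2-aminophenyl to a 4-nitrophenyl group on the shared core.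

Compound 3 `O=C(CCCCCCc1ccccc1)c1ncc(-c2ccc(O)cc2)o1` has not yet been measured. It differs from compound 2 by hydroxy in place of nitro on an aromatic carbon, para to a large group. The measured step bears on this only loosely: it exchanged amino, which brings a hydrogen-bond donor, for nitro, which brings none, and the number fell sharply. Compound 3 puts a hydrogen-bond donor back at the place nitro held. Among the compounds with values here, the expectation is therefore that the number rises again, a step of a 5.0-fold higher number from compound 2 to compound 3 (0.70 log units; beyond the scatter), with wide uncertainty since no measured pair contains hydroxy. Compound 3 is expected at 250 nM, with a range from 60 nM to 1000 nM.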

Compound 3, inhibition constant: 140 nM
Estimate against measurement, compound 3: 1.8-fold (0.25 log units) above; the range from low to high includes it.
By their numbers in this assay, from the lowest: compound 2; then compound 3; then compound 1.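

Exchanging nitro for hydroxy, para to a large group, gives a 2.8-fold higher number from compound 2 to compound 3 (0.45 log units; beyond the scatter) in this assay, so the nitro group of compound 2 can be replaced at this place with only a modest change in the number. Measured from the other side, the change from 2-aminophenyl to 4-hydroxyphenyl gives a 5.4-fold lower number from compound 1 to compound 3 (0.73 log units; beyond the scatter) and keeps compound 3 clearly on the stronger side of compound 1, so carrying a hydrogen-bond donor on this ring does not by itself bring the number back up to that of compound 1. Nothing measured here explains why nitro gives a lower number than hydroxy, or why either gives a lower number than 2-aminophenyl.

The compounds shown leave open whether the lower number belongs to nitro alone or would also appear with other groups at this place, such as methoxy, a carboxylic acid or a plain hydrogen. They also cannot separate the effect of the group from the effect of where it sits, as amino appears here only as 2-aminophenyl and hydroxy only as 4-hydroxyphenyl.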